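Methylsulfanyl in place of methyl in compound 3

The compounds below may be only part of what the source reports. "The series", "measured", "known", "first", "only" and "open" are said of these compounds alone.

In a functional assay (aorta) with Oryctolagus cuniculus as the target (a lower number here means tighter binding, a higher number weaker binding), compound 1 (`CCCCc1nc2c(C)cccc2n1Cc1cc(Cl)c(O)c(Cl)c1`) gives 20 nM and compound 2 (`CCCc1nc2c(C)ccnc2n1Cc1cc(Cl)c(O)c(Cl)c1`) gives 1.26 nM. Compound 3 (`Cc1ccnc2c1nc(C)n2Cc1ccc(-c2ccccc2C(=O)O)cc1`) gives 50.1 nM, the highest number of the three, with both gaps beyond the scatter. Compound 4 (`CSc1nc2c(C)ccnc2n1Cc1ccc(-c2ccccc2C(=O)O)cc1`) carries methylsulfanyl in place of methyl on an aromatic carbon. Going by the values given here, no measured pair isolates this change. Compound 1, with a butyl chain at that place, gives 20 nM and compound 2, with a propyl chain there, gives 1.26 nM, but both also differ from compound 3 elsewhere, so the guidance is weak. In this assay the expected change is a 4.2-fold lower number from compound 3 to compound 4 (0.62 log units; beyond the scatter), a moderate move to a lower number, beyond the scatter. For compound 4 the estimated value is 12 nM, with an expected range of 3 nM to 45 nM.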

Compound 4, dissociation constant: 10 nM
Compound 4: the middle estimate sits 1.2-fold (0.08 log units) above what was measured, within the range that was stated.
By their numbers in this assay, from the lowest: compound 2; then compounds 4 and 1 (each within the scatter of the next); then compound 3.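

In this assay, going by these compounds alone, the first single-place change gives a 5.0-fold lower number from compound 3 to compound 4 (0.70 log units; beyond the scatter), so the aromatic carbon between two ring nitrogen atoms does respond to its substituent with the rest of the structure held fixed. Methylsulfanyl is accepted there in place of methyl, and the number moves lower. Nothing measured here explains the shift.

Open, on these data alone, is how ethylsulfanyl or an amine at this place would read on the core of compound 3. Also open, as far as these compounds go, is whether a propyl chain there would move the number further on that core.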